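Swapping the Amide Tail on a Shared Hydroxamate Core

The source may report more compounds than this note shows. Statements on the series, on what has been measured and on what is new or still open speak of the compounds shown alone.

Compound 1, `CN(C)c1ccc(C(=O)N[C@@H](CCCCCC(=O)NO)C(=O)NCc2ccccc2)cc1`, gives 12000 nM in a functional assay on NFF cells (Homo sapiens) for antiproliferative activity; a higher number here means a weaker inhibitor, a lower number a stronger inhibitor.
Compound 2, `O=C(/C=C/c1ccccc1)N[C@@H](CCCCCC(=O)NO)C(=O)NCc1ccccc1`, gives 4010 nM in this assay.
Compound 3, `CN(C)c1ccc(C(=O)N[C@@H](CCCCCC(=O)NO)C(=O)Nc2cccc3cccnc23)cc1`, gives 570 nM in this assay.

Compound 4, `O=C(/C=C/c1ccccc1)N[C@@H](CCCCCC(=O)NO)C(=O)Nc1cccc2cccnc12`, has not yet been measured. It differs from compound 3 in one place: 2-phenylethenyl in place of 4-(dimethylamino)phenyl on a carbonyl carbon. This is the same change already made once before, which gave a 3.0-fold lower number from compound 1 to compound 2 (0.48 log units; beyond the scatter). The two starting points differ in their core: quinolin-8-yl in place of benzyl on an amide-type nitrogen, a change that gave a 21-fold lower number from compound 1 to compound 3 (1.32 log units; beyond the scatter). The place of the change is the same in both pairs, so it counts as the same change.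

Compound 4 is expected to show a 2.9-fold lower number from compound 3 to compound 4 (0.45 log units; beyond the scatter) in this assay. This expectation rests on the earlier step, a 3.0-fold lower number from compound 1 to compound 2 (0.48 log units; beyond the scatter), applied to compound 3 at 570 nM. Some allowance is made in the range, since the two changes need not add up exactly. Compound 4 is therefore estimated at 200 nM, with a range from 70 nM to 600 nM.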

Compound 4, half-maximal inhibitory concentration: 1240 nM
The estimate for compound 4 lay 6.2-fold (0.79 log units) below the measured number; measured number above the stated range.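

Putting 2-phenylethenyl in place of 4-(dimethylamino)phenyl on a carbonyl carbon did not carry over between cores in this assay: with quinolin-8-yl on the amide-type nitrogen, the swap gave a 2.2-fold higher number from compound 3 to compound 4 (0.34 log units; beyond the scatter), so its direction reversed: the same change on two cores in this assay, a 3.0-fold lower number (0.48 log units; beyond the scatter) from compound 1 to compound 2 and a 2.2-fold higher number (0.34 log units; beyond the scatter) from compound 3 to compound 4, 6.5-fold (0.81 log units) apart, beyond the scatter of two such steps

Seen from the other side, quinolin-8-yl in place of benzyl still lowered the number, giving a 3.2-fold lower number from compound 2 to compound 4 (0.51 log units; beyond the scatter), but the size of this gain depended on the group at the other end: the same change on two cores in this assay, a 21-fold lower number (1.32 log units; beyond the scatter) from compound 1 to compound 3 and a 3.2-fold lower number (0.51 log units; beyond the scatter) from compound 2 to compound 4, 6.5-fold (0.81 log units) apart, beyond the scatter of two such steps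

The two changes therefore do not simply add up in these four compounds, but this does not show why, nor how general the reversal is.

As far as these compounds go, it remains open whether a plain phenyl or a longer carbon chain on that carbonyl carbon would also behave differently on the two cores.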